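A few compounds are considered here, and "the series" means these few. Any claim that something is new, unique, unknown or untested is made for them only; others in the source may bear on it.

Compound 1 `COc1cc(-c2nnc3n2NC(c2ccco2)C(C(=O)c2ccc(F)c(F)c2)S3)cc(OC)c1OC`: 52400 nM in a functional assay on HepG2 cells (Homo sapiens) for cytotoxicity, read by MTT assay, with a stated time of 48 h; a higher number here means a weaker inhibitor, a lower number a stronger inhibitor.
Compound 2 `COc1cc(-c2nnc3n2NC(c2ccco2)C(C(=O)C2CC2)S3)cc(OC)c1OC`: > 100000 nM in this assay, which is a limit of this assay and not a number.
Compound 3 `COc1cc(-c2nnc3n2NC(c2ccco2)C(C(=O)c2ccc(C)cc2)S3)cc(OC)c1OC`: 17400 nM in this assay.

Among these, compound 3 has the lowest of the two numbers. Its nearest neighbour is compound 1, and the step of a 3.0-fold lower number from compound 1 to compound 3 (0.48 log units; beyond the scatter) is beyond the scatter. The step of an at least 5.7-fold lower number from compound 2 to compound 3 (0.75 log units; beyond the scatter) is anchored on a limit, as the limit of > 100000 nM in this assay, at which 1 of the 3 values shown sits, shows, while an at least 1.9-fold higher number from compound 1 to compound 2 (0.28 log units; that floor lies within the scatter) cannot be separated from the scatter.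

Compound 4 `COc1cc(-c2nnc3n2NC(c2ccco2)C(C(=O)c2ccccc2F)S3)cc(OC)c1OC` is not yet measured. Its difference from compound 3 is 2-fluorophenyl in place of 4-methylphenyl on a carbonyl carbon.

Among the measured compounds shown here, the only measured step that bears on this change is the one from compound 1 to compound 3, where a fluorinated phenyl gave way to 4-methylphenyl on the carbonyl carbon and the number fell by a 3.0-fold lower number from compound 1 to compound 3 (0.48 log units; beyond the scatter). Compound 4 moves back towards a fluorinated phenyl, though with a single fluorine in a different place, so a modest rise in the number, towards that of compound 1, is expected in this assay. Compound 4 is therefore estimated at 30000 nM, within 12000 nM to 75000 nM. This expectation corresponds to a step of a 1.7-fold higher number from compound 3 to compound 4 (0.24 log units; within the scatter).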

Compound 4, half-maximal inhibitory concentration: > 100000 nM
Compound 4 was reported as a limit; the forecaster's own chance of this, stated with the estimate: 10%; at least 3.3-fold (0.52 log units) between middle value and limit.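

In this assay, 2-fluorophenyl in place of 4-methylphenyl on the carbonyl carbon gives an at least 5.7-fold higher number from compound 3 to compound 4 (0.75 log units; beyond the scatter), so this change carries compound 3 from a measured number to a reported limit, and both fluorinated phenyl compounds now have higher numbers than compound 3. Among the compounds shown here, the comparison with the 3,4-difluorophenyl group is far less clear, with an at least 1.9-fold higher number from compound 1 to compound 4 (0.28 log units; that floor lies within the scatter), so the data do not separate the single fluorine of compound 4 from the two fluorines of compound 1. Compound 4 is reported only as a limit, and compound 2 sits at that same limit, so the step between them cannot be read: the limit of > 100000 nM in this assay, at which 2 of the 4 values shown sit.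

As far as these compounds go, whether the lower number of compound 3 depends on its methyl group, or whether the fluorines alone raise the number, stays open, and a plain phenyl or a methoxyphenyl group on the same carbonyl carbon would bear on that. Also open, from the compounds shown here alone, is how an amine or a carboxylic acid on this phenyl ring would read in this assay.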